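The source may hold more compounds than are shown below. What is called first, only, known or untested is meant among the compounds shown, and "the series" means these compounds.

Compound 1, `Cc1ccsc1/C=C(/SCc1ccc(Cl)cc1)C(=O)c1ccc(Br)cc1`: in a functional assay on DU-145 cells (Homo sapiens) for inhibition, read by trypan blue exclusion, with a stated time of 96 h (a higher number here means a weaker inhibitor of growth, a lower number a stronger inhibitor of growth), compound 1 gives 25000 nM.
Compound 2, `Cc1ccsc1/C=C(/SCc1ccc(Cl)cc1)C(=O)c1ccc(Cl)cc1`: in this assay compound 2 gives 50000 nM.
Compound 3, `O=C(/C(=C\c1cccc(Cl)c1Cl)SCc1ccc(Cl)cc1)c1ccc(Cl)cc1`: in this assay compound 3 gives 10000 nM.

Compound 2 has the highest number of the three. Against compound 1 the gap is a 2.0-fold higher number from compound 1 to compound 2 (0.30 log units; within the scatter), which is within the scatter, so the two cannot be ranked. Against compound 3 the gap is a 5.0-fold lower number from compound 2 to compound 3 (0.70 log units; beyond the scatter), a modest step beyond the scatter, so compound 3 is the stronger growth inhibitor of that pair.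

Compound 4, `Cc1ccsc1/C=C(/SCc1ccc(Cl)cc1Cl)C(=O)c1ccc(Cl)cc1`, differs from compound 2 in one place: chloro in place of hydrogen on an aromatic carbon. Put another way, the 4-chlorobenzyl group on the sulfur becomes a 2,4-dichlorobenzyl group.

Neither measured step touches this part of the molecule. The step from compound 1 to compound 2 swaps a halogen on the ketone-bound ring and stays within the scatter; the step from compound 2 to compound 3 replaces the ring at the other end of the double bond. There is therefore no direct guide for an added chloro on the benzyl group, and no step beyond the scatter is expected in this assay.

For compound 4 the expected value in this assay is 40000 nM, with a range from 15000 nM to 100000 nM. This estimate means a step of a 1.3-fold lower number from compound 2 to compound 4 (0.10 log units; within the scatter), within the scatter.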

Compound 4, concentration for 50% growth inhibition: 10000 nM
Compound 4: the middle estimate sits 4.0-fold (0.60 log units) above what was measured; the whole stated range lies above it.
By their numbers in this assay, from the lowest: compounds 3 and 4 (each within the scatter of the next); then compounds 1 and 2 (each within the scatter of the next).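

In this assay, one added chlorine atom, turning the 4-chlorobenzyl group on the sulfur into a 2,4-dichlorobenzyl group, gives a 5.0-fold lower number from compound 2 to compound 4 (0.70 log units; beyond the scatter), a modest step beyond the scatter, and this makes compound 4 the stronger growth inhibitor of the pair with compound 2. Among these compounds, the earlier steps changed the ketone-bound ring and the ring at the other end of the double bond, so this is the first sign that the benzyl group also matters: a single heavy atom, placed on an aromatic carbon ortho to a large group, is enough to move the number beyond the scatter. The data shown offer no measurement that explains this gain.

From the compounds shown here alone, it remains open whether the gain belongs to chlorine in particular, or whether a methyl group, a methoxy group or a fluorine atom on the same carbon would give a similar step. Also open, going by these compounds, is whether the 2,4-dichlorobenzyl group would bring a similar step on compounds carrying the 2,3-dichlorophenyl group or the bromo-substituted ketone ring.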